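The source may hold more compounds than are shown below. What is called first, only, known or untested is meant among the compounds shown, and "the series" means these compounds.

Within the data shown here, compound 2 `O=C(c1ccccc1)N1CCC(NCCSC(c2ccc(F)cc2)c2ccc(F)cc2)CC1` stands lowest of the two numbers measured so far in an assay on membranes from striatum (strain Sprague-Dawley) for displacement of a labelled ligand from sodium-dependent dopamine transporter (Rattus norvegicus), read by scintillation counting, with a stated time of 120 min (on this read-out higher numbers stand for weaker inhibition and lower numbers for stronger inhibition), where compound 2 gives 4.51 nM. Among the measured compounds shown here, its only neighbour is compound 1 `Fc1ccc(C(SCCNC2CCN(Cc3ccc(Cl)cc3)CC2)c2ccc(F)cc2)cc1`, which in this assay gives 39.6 nM; the one measured step, an 8.8-fold lower number from compound 1 to compound 2 (0.94 log units; beyond the scatter), comes from putting benzoyl in place of 4-chlorobenzyl on the ring nitrogen. Compound 3 `O=C(c1cc2ccccc2[nH]1)N1CCC(NCCSC(c2ccc(F)cc2)c2ccc(F)cc2)CC1` differs from compound 2 by 1H-indol-2-yl in place of phenyl on a carbonyl carbon. For the measured compounds named here, no measured step touches this carbonyl substituent, so the step from compound 1 to compound 2 bears on it only in showing that the group on that nitrogen matters. With nothing more to lean on, the expectation for this assay is a step no larger than the measured scatter, in either direction, expressed as a 1.1-fold higher number from compound 2 to compound 3 (0.04 log units; within the scatter). On that basis compound 3 is estimated at 5 nM, within a range of 1.5 nM to 20 nM.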

Compound 3, inhibition constant: 177 nM
For compound 3 the middle estimate is 35-fold (1.55 log units) below the measured one; measured number outside the range, above it.
By their numbers in this assay, from the lowest: compound 2; then compound 1; then compound 3.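

In this assay the substituent on this carbonyl carbon proves to matter a great deal: with 1H-indol-2-yl in place of phenyl there is a 39-fold higher number from compound 2 to compound 3 (1.59 log units; beyond the scatter), a large step in the weaker direction. The second new step, a 4.5-fold higher number from compound 1 to compound 3 (0.65 log units; beyond the scatter), puts the (1H-indol-2-yl)carbonyl group behind even 4-chlorobenzyl on the ring nitrogen, so among these compounds a carbonyl on that nitrogen does not by itself bring the lower number, since benzoyl brings it and (1H-indol-2-yl)carbonyl does not. No measurement shown here explains this loss.

Still open, on these data alone, is whether the loss follows the hydrogen on the indole nitrogen or the added fused ring, which 1-methylindol-2-yl or benzofuran-2-yl on the same carbonyl could separate. Also open, as far as these compounds go, is how a smaller ring such as 2-pyrrolyl or 2-furyl would compare with phenyl there.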